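The compounds below may be only part of what the source reports. "The series", "measured", "known", "first", "only" and "open" are said of these compounds alone.

Of the compounds shown here, two with a shared core have been measured in an assay on cell membranes from spleen (Cavia porcellus) for binding affinity to leukotriene B4 receptor 1 (Homo sapiens); a lower number here means a stronger inhibitor, a higher number a weaker inhibitor. Compound 1 `CC(CCCCOc1cc(-c2ccccc2)cc(-c2ccccc2F)n1)C(=O)O` gives 4 nM in this assay. Compound 2 `O=C(O)CCCCCOc1cc(-c2ccccc2)cc(-c2ccccc2)n1` gives 3 nM in this assay, the lowest of the two numbers, yet compound 1 sits within the scatter of it, so the two cannot be told apart on these data.

Compound 3 `CC(CCCCOc1cc(-c2ccccc2)cc(-c2ccccc2)n1)C(=O)O` has not yet been measured. It differs from compound 2 in one place: methyl in place of hydrogen on a saturated chain carbon bound to a carbonyl carbon and a saturated chain carbon, a methyl in place of hydrogen on a saturated chain carbon bound to a carbonyl carbon and a saturated chain carbon. Among the measured compounds shown here, no pair of measured compounds shows this single change on its own. Compound 1 already carries that methyl together with a further change and gives 4 nM, a number within the scatter of compound 2. The step from compound 2 to compound 3 is expected to be small, a 1.2-fold higher number from compound 2 to compound 3 (0.07 log units; within the scatter), with no direction beyond the scatter. Compound 3 is expected to give about 3.5 nM in this assay, between 1.5 nM and 8 nM.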

Compound 3, half-maximal inhibitory concentration: 4 nM
For compound 3 the middle estimate is 1.1-fold (0.06 log units) below the measured one, within the range that was stated.
By their numbers in this assay, from the lowest: compounds 2, 1 and 3 (each within the scatter of the next).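

In this assay, the methyl on a saturated chain carbon bound to a carbonyl carbon and a saturated chain carbon can now be read on its own: the step is a 1.3-fold higher number from compound 2 to compound 3 (0.12 log units; within the scatter), so compounds with and without it cannot be told apart here. Among the compounds shown here, the fluoro can also be read alone for the first time, and hydrogen in its place on an aromatic carbon gives no change at the digits printed from compound 1 to compound 3 (within the scatter), so this swap likewise leaves no visible mark on the number. Nothing available gives a reason for either result.

As far as these compounds go, only hydrogen and methyl appear at this chain carbon, so it remains open whether a larger group such as ethyl, or a hydroxyl or an amine, would be accommodated as well. From the compounds shown here alone, the effect of a longer chain, or of an amide in place of the carboxylic acid, also remains open.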